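The compounds below may be only part of what the source reports. "The series", "measured", "known", "first", "only" and "open" are said of these compounds alone.

Measured in a functional assay on LoVo cells (Homo sapiens) for antiproliferative activity, read by MTT assay, with a stated time of 72 h; on this read-out higher numbers stand for weaker inhibition and lower numbers for stronger inhibition:

Compound 1 `Cn1cc(-c2nn(Cc3ccc(C(=O)NC4CCCC4)cc3)c(=O)c3ccccc23)cn1` gives 23700 nM
Compound 2 `Cc1noc(C)c1-c1nn(Cc2ccc(C(=O)NC3CCN(C)CC3)cc2)c(=O)c2ccccc12` gives > 100000 nM (a limit)

In this assay compound 2 is reported as > 100000 nM, which is a limit of the assay and not a number. Compound 3 `Cc1noc(C)c1-c1nn(Cc2ccc(C(=O)NC3CCCC3)cc2)c(=O)c2ccccc12` differs from compound 2 in one place, with cyclopentyl in place of 1-methylpiperidin-4-yl on an amide-type nitrogen. Among the compounds with values here, no measured pair shows this change, so the expectation rests on compound 1, which also holds a cyclopentyl group on an amide-type nitrogen and gives 23700 nM in this assay. A fall in the read-out beyond the usual scatter, toward stronger inhibition, is expected, although compound 2 offers only a limit to start from. The expected change is an at least 5.0-fold lower number from compound 2 to compound 3 (0.69 log units; beyond the scatter) in this assay. For compound 3 the estimate is 20000 nM, with an expected range from 6000 nM to 70000 nM.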

Compound 3, half-maximal inhibitory concentration: > 100000 nM
Compound 3 was reported as a limit; the forecaster's own chance of this, stated with the estimate: 20%; middle value at least 5.0-fold (0.69 log units) away from the limit.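

With the cyclopentyl group kept on the amide-type nitrogen, 3,5-dimethyl-1,2-oxazol-4-yl in place of 1-methyl-1H-pyrazol-4-yl on an aromatic carbon gives an at least 4.2-fold higher number from compound 1 to compound 3 (0.62 log units; beyond the scatter) in this assay, which means weaker inhibition. Cyclopentyl on the amide-type nitrogen is therefore not enough on its own to bring a compound into the measurable range, and the group on the aromatic carbon counts as well. The swap of 1-methylpiperidin-4-yl for cyclopentyl itself cannot be read, because compound 2 and compound 3 both stop at the same ceiling: the limit of > 100000 nM in this assay, at which 2 of the 3 values shown sit.

On these data alone, whether 1-methylpiperidin-4-yl on the amide-type nitrogen would lower or raise the number when 1-methyl-1H-pyrazol-4-yl sits on the aromatic carbon remains open. Also open, as far as these compounds go, is how a plain phenyl group on that aromatic carbon, or a morpholine-bearing chain on the amide-type nitrogen, would read in this assay.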